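Methyl on the fused ring of the sulfonyl series

The compounds below may be only part of what the source reports. "The series", "measured", "known", "first", "only" and "open" are said of these compounds alone.

Measured compounds:
compound 1 `CSc1nn2cccnc2c1S(=O)(=O)c1ccccc1` — 115 nM
compound 2 `CNc1nn2cccnc2c1S(=O)(=O)c1ccccc1` — 3.89 nM

Compound 1 `CSc1nn2cccnc2c1S(=O)(=O)c1ccccc1` gives 115 nM in a functional assay on HEK293 cells for antagonist activity at 5-hydroxytryptamine receptor 6 (Homo sapiens), read by cAMP accumulation, with a stated time of 2 h (on this read-out lower numbers stand for stronger inhibition and higher numbers for weaker inhibition), the higher of the two numbers recorded so far; its nearest measured neighbour is compound 2 `CNc1nn2cccnc2c1S(=O)(=O)c1ccccc1`, which gives 3.89 nM in this assay. Within the data shown here, the single measured step, a 30-fold lower number from compound 1 to compound 2 (1.47 log units; beyond the scatter), replaces the methylsulfanyl group and leaves the fused ring untouched.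

Compound 3 `CSc1nn2c(C)ccnc2c1S(=O)(=O)c1ccccc1` is not yet measured. It differs from compound 1 by methyl in place of hydrogen on an aromatic carbon. The methylsulfanyl group and the phenylsulfonyl group are both retained. Among the measured compounds shown here, no measured pair shows a change at this position of the core, so nothing measured bears directly on this step; the step from compound 1 to compound 2 concerns a different site and gives no guide to the size here. A step no larger than the usual scatter is therefore expected, a 1.2-fold lower number from compound 1 to compound 3 (0.06 log units; within the scatter), with no direction favoured. Compound 3 is estimated at 100 nM in this assay, with an expected range from 30 nM to 350 nM.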

Compound 3, inhibition constant: 22.9 nM
Compound 3: the middle estimate sits 4.4-fold (0.64 log units) above what was measured; the measured number lies below the stated range.
By their numbers in this assay, from the lowest: compound 2; then compound 3; then compound 1.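

In this assay, the fused ring of the core proves to be a site that moves the number: methyl in place of hydrogen on an aromatic carbon next to the ring nitrogen gives a 5.0-fold lower number from compound 1 to compound 3 (0.70 log units; beyond the scatter), a modest step but one beyond the scatter. The series therefore responds at two separate sites of compound 1, with the change at the methylsulfanyl group giving the large step of a 30-fold lower number from compound 1 to compound 2 (1.47 log units; beyond the scatter) and this single added methyl giving the modest one. No measurement offered here accounts for the gain at this position.

Open is whether the methyl step holds when the methylsulfanyl group is replaced by methylamino as in compound 2: the compounds shown carry the two changes only apart, so nothing indicates whether they add up. Also open, going by these compounds, is how specific the step is to methyl at this carbon, since one substituent gives no trend, and an ethyl group, a methoxy group, chlorine or an amine there could show whether size or kind of group matters on this ring.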